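Replacing an aryl ether with a cyanobenzyl group

A few compounds are considered here, and "the series" means these few. Any claim that something is new, unique, unknown or untested is made for them only; others in the source may bear on it.

Three measured compounds share one core and differ only in the ring hung off the oxygen: compound 1 `COc1cccc(CNCCCNc2ccnc3cc(Oc4ccc(Cl)cc4)ccc23)c1O`, compound 2 `COc1ccc(Oc2ccc3c(NCCCNCc4cccc(OC)c4O)ccnc3c2)cc1` and compound 3 `COc1cccc(Oc2ccc3c(NCCCNCc4cccc(OC)c4O)ccnc3c2)c1`. In an ADME assay for permeability, using PAMPA, with a stated time of 30 min, at pH 7.4 (on this read-out lower numbers stand for lower permeability and higher numbers for higher permeability), compound 1 gives 317 10^-6 cm/s, compound 2 gives 317 10^-6 cm/s and compound 3 gives 317 10^-6 cm/s, so compound 3 stands level with both others. The three steps among them, no change at the digits printed from compound 1 to compound 2 (within the scatter), no change at the digits printed from compound 1 to compound 3 (within the scatter) and no change at the digits printed from compound 2 to compound 3 (within the scatter), all stay within the scatter.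

Compound 4 `COc1cccc(CNCCCNc2ccnc3cc(Cc4ccc(C#N)cc4)ccc23)c1O` is not yet measured. It differs from compound 3 by 4-cyanobenzyl in place of 3-methoxyphenoxy on an aromatic carbon. For the measured compounds named here, none of the measured steps touches the oxygen link or brings in a nitrile; they only show that swapping substituents on the outer ring left this assay unchanged. Going by the values given here, with no step pointing either way, the expectation for compound 4 is a step of a 1.1-fold lower number from compound 3 to compound 4 (0.02 log units; within the scatter), that is, nothing beyond the scatter. Compound 4 is therefore estimated at 300 10^-6 cm/s, within a range of 150 10^-6 cm/s to 420 10^-6 cm/s.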

Compound 4, apparent permeability: 23 10^-6 cm/s
For compound 4 the middle estimate is 13-fold (1.12 log units) above the measured one; measured number below the stated range.
By their numbers in this assay, from the lowest: compound 4; then compounds 1, 2 and 3 (each within the scatter of the next).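

Swapping substituents on the outer ring left the numbers level, but this position is not indifferent to every change: replacing the whole aryloxy group with 4-cyanobenzyl in this assay gives a 14-fold lower number from compound 3 to compound 4 (1.14 log units; beyond the scatter), and the other two compounds give the same large step, a 14-fold lower number from compound 2 to compound 4 (1.14 log units; beyond the scatter) and a 14-fold lower number from compound 1 to compound 4 (1.14 log units; beyond the scatter). The flat read-out across compounds 1, 2 and 3 therefore held only for changes on the outer ring, and it does not extend to a change at the aromatic carbon of the shared core where that group is attached. Nothing available here accounts for the size of this step.

This single swap changes both the oxygen link and the ring substituent, leaving open which of the two goes with the lower number. A plain benzyl group and a 4-cyanophenoxy group are the two pieces that would separate them.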